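Dropping One Methoxy Group: A Flat Step Is Expected

The source may hold more compounds than are shown below. What is called first, only, known or untested is meant among the compounds shown, and "the series" means these compounds.

Measured so far:
compound 1 `COc1ccc(-c2cc(/C=C/C(=O)c3ccc(N)cc3)[nH]n2)cc1` gives 105% in a functional assay on SK-OV-3 cells (Homo sapiens) for cytotoxicity, read by sulforhodamine B assay, with a stated time of 48 h, tested at 1 uM; on this read-out lower numbers stand for a stronger effect and higher numbers for a weaker effect at the one concentration tested
compound 2 `COc1cc(-c2cc(/C=C/C(=O)c3ccc(N)cc3)[nH]n2)cc(OC)c1OC` gives 104%
compound 3 `COc1cc(-c2cc(/C=C/C(=O)c3ccc(Cl)c(Cl)c3)[nH]n2)cc(OC)c1OC` gives 89%

Compound 2 stands second highest of these three numbers. Among the compounds with values here, compound 1 sits within the scatter of it, while the only step beyond the scatter, a number 15 percentage points lower from compound 2 to compound 3 (beyond the scatter), changes the group on the carbonyl carbon at the other end of the molecule. Compound 4 `COc1ccc(-c2cc(/C=C/C(=O)c3ccc(N)cc3)[nH]n2)cc1OC` differs from compound 2 in one place: hydrogen in place of methoxy on an aromatic carbon. Within the data shown here, no measured step alters this ring in a single place. Compound 1 and compound 2, whose rings carry different numbers of methoxy groups, show values within the scatter of each other, so the methoxy count on this ring has not moved the read-out. The step of a number 1 percentage points lower from compound 2 to compound 4 (within the scatter) is therefore expected to remain within the scatter. Compound 4 is estimated at 103%, ranging from 90% to 115%.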

Compound 4, a percentage reported as activity, at one concentration (the size of the read-out at that concentration, not a potency): 97%
Compound 4: the middle estimate sits 6 percentage points above what was measured, and the stated range covers the measured number.
By their numbers in this assay, from the lowest: compounds 3, 4, 2 and 1 (each within the scatter of the next, the first and the last beyond it).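

Within the data shown here, this is the first measured step that alters this ring in a single place. Hydrogen in place of methoxy gives a number 7 percentage points lower from compound 2 to compound 4 (within the scatter), and the opposite swap, methoxy in place of hydrogen at another ring carbon, gives a number 8 percentage points lower from compound 1 to compound 4 (within the scatter). Neither methoxy step can be told apart from repeat-measurement scatter, and no measurement available here offers an explanation for this result. From the compounds shown here alone, whether a different group on this aromatic carbon, such as an amine, a carboxylic acid or a longer chain, would shift the read-out remains open.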